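The source may hold more compounds than are shown below. What is called first, only, known or untested is meant among the compounds shown, and "the series" means these compounds.

Measured in a functional assay on HT-29 cells (Homo sapiens) for antiproliferative activity, read by MTT assay, with a stated time of 72 h; a lower number here means a stronger inhibitor, a higher number a weaker inhibitor:
- compound 1 `C=C(Br)C(=O)Nc1ccc2c(c1)/C(=C\c1ccc(C)s1)C(=O)N2`: 300 nM
- compound 2 `C=C(Br)C(=O)Nc1ccc2c(c1)/C(=C\c1sccc1C)C(=O)N2`: 330 nM

Compound 2 stands level with compound 1 in this assay. For the measured compounds named here, the one measured step, a 1.1-fold higher number from compound 1 to compound 2 (0.04 log units; within the scatter), lies within the scatter and swaps 5-methylthiophen-2-yl for 3-methylthiophen-2-yl.

Compound 3 `C=C(Br)C(=O)Nc1ccc2c(c1)/C(=C/c1sccc1C)C(=O)N2` is next: the two compounds have the same atoms and bonds and differ only in configuration as drawn: 1 of 1 stereo elements differ; a double bond is drawn E in compound 2 and Z in compound 3. The two compounds have the same atoms and bonds, and the double bond is drawn E in compound 2 and Z in compound 3.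

The measured step bears on this only indirectly, since compound 1 and compound 2 share the drawn configuration. Going by the values given here, no measured pair tests that configuration, so the data give no direction and no size for such a change. No shift beyond the scatter can be predicted, though the range stays wide.

The expected change is a 1.2-fold higher number from compound 2 to compound 3 (0.08 log units; within the scatter). For compound 3 the estimated value is 400 nM, with an expected range of 130 nM to 1300 nM.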

Compound 3, half-maximal inhibitory concentration: 1200 nM
For compound 3 the middle estimate is 3.0-fold (0.48 log units) below the measured one; measured number inside the range.
By their numbers in this assay, from the lowest: compounds 1 and 2 (each within the scatter of the next); then compound 3.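

In this assay, for the compounds shown here, the drawn configuration of the double bond is the first change to move the number beyond the scatter: a 3.6-fold higher number from compound 2 to compound 3 (0.56 log units; beyond the scatter). The earlier step changed only the methyl placement on the thiophene and stayed within the scatter, so compounds 1 and 2 gave no reading on this double bond. The shift can be assigned to the double bond alone, with the E drawing favoured over the Z drawing for 3-methylthiophen-2-yl, because no other structural feature changes: the fact that compounds 2 and 3 differ only in the configuration as drawn

As far as these compounds go, whether the same preference holds with 5-methylthiophen-2-yl remains open, since this single pair carries the 3-methylthiophen-2-yl group only. Also open, from the compounds shown here alone, is how either configuration would respond to an amine or a carboxylic acid in place of the methyl.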